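A few compounds are considered here, and "the series" means these few. Any claim that something is new, unique, unknown or untested is made for them only; others in the source may bear on it.

Measured in a functional assay on C8166 cells (Homo sapiens) for cytotoxicity, read by MTT assay, with a stated time of 72 h; a lower number here means that less compound is tolerated, a higher number that more compound is tolerated:
- compound 1 `Cc1ccc(S(=O)(=O)N2CC3(C[C@H]2C(=O)N/N=C/c2ccccc2[N+](=O)[O-])SCCS3)cc1`: 65000 nM
- compound 2 `Cc1ccc(S(=O)(=O)N2CC3(C[C@H]2C(=O)N/N=C/c2cccc([N+](=O)[O-])c2)SCCS3)cc1`: > 395000 nM, a limit of the assay
- compound 3 `COc1cc(/C=N/NC(=O)[C@@H]2CC3(CN2S(=O)(=O)c2ccc(C)cc2)SCCS3)cc(OC)c1OC`: 327000 nM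

Compound 3 holds the higher of the two actual numbers, with a 5.0-fold higher number from compound 1 to compound 3 (0.70 log units; beyond the scatter). Compound 4 `COc1ccccc1/C=N/NC(=O)[C@@H]1CC2(CN1S(=O)(=O)c1ccc(C)cc1)SCCS2` carries 2-methoxyphenyl in place of 3,4,5-trimethoxyphenyl on a carbon with a double bond to nitrogen. Among the measured compounds shown here, no measured step makes this exact exchange. Compound 1, with 2-nitrophenyl, has the lowest standing, and replacing that group also gave an at least 6.0-fold higher number from compound 1 to compound 2 (0.78 log units; beyond the scatter). The remaining comparison, an at least 1.2-fold lower number from compound 2 to compound 3 (0.08 log units; that floor lies within the scatter), has a floor within the scatter. A modest fall in this assay is therefore expected, smaller than the rise to compound 3. The expected change is a 2.2-fold lower number from compound 3 to compound 4 (0.34 log units; beyond the scatter). For compound 4 the estimated value is 150000 nM, with an expected range of 50000 nM to 400000 nM.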

Compound 4, half-maximal cytotoxic concentration: 388000 nM
Estimate against measurement, compound 4: 2.6-fold (0.41 log units) below; low and high end bracket the measured number.
By their numbers in this assay, from the lowest: compound 1; then compounds 3 and 4 (each within the scatter of the next). At a limit, above all of these: compound 2.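

Replacing nitro with methoxy on an aromatic carbon gives a clear rise in this assay (a 6.0-fold higher number from compound 1 to compound 4 (0.78 log units; beyond the scatter)), so among the compounds shown the low number stays with 2-nitrophenyl alone. With 2-methoxyphenyl in place of 3,4,5-trimethoxyphenyl on a carbon with a double bond to nitrogen, the step lies within the scatter (a 1.2-fold higher number from compound 3 to compound 4 (0.07 log units; within the scatter)), so this assay does not tell these two groups apart at this place. Compound 2 stands at a limit, so this step cannot be read (an at least 1.0-fold lower number from compound 2 to compound 4 (0.00 log units; that floor lies within the scatter)): the limit of > 395000 nM in this assay, at which 1 of the 4 values shown sits.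

The compounds shown leave open whether a phenyl group carrying an amine or a carboxylic acid would stay with compound 3 and compound 4 or fall toward compound 1.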